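This account rests on a few compounds, and the source may have more. Where it says the series, first, only, none or still open, it means among the compounds named here.

Four close relatives of one unsaturated ester and ketone family are compared here. Compound 1 is `CCCOC(=O)/C=C(C)/C=C/CC(C)CCCC(C)C`, compound 2 is `CCC(C)OC(=O)/C=C(C)/C=C/CC(C)CCCC(C)C` and compound 3 is `CCCC(=O)/C=C(C)/C=C/CC(C)CCCC(C)C`; all three have been measured. Compound 4, `CC(/C=C/CC(C)CCCC(C)C)=C\C(=O)CC(C)C`, has not.

In a physicochemical assay for lipophilicity (a lower number here means a more polar compound, a higher number a more lipophilic compound), compound 1 gives 7.28. Compound 2 gives 7.69, and compound 3 gives 6.81 in this assay, the lowest of the three.

Compound 1 and compound 2 differ by methyl in place of hydrogen on a saturated chain carbon bound to an oxygen next to a carbonyl group and a saturated chain carbon. That change made a step of a number 0.41 log units higher from compound 1 to compound 2 (beyond the scatter). Compound 3 carries a different core from compound 1, and the two cores differ by propyl in place of propoxy on a carbonyl carbon, which gave a number 0.47 log units lower from compound 1 to compound 3 (beyond the scatter). Between compound 2 and compound 3 the step was a number 0.88 log units lower from compound 2 to compound 3 (beyond the scatter).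

Compound 4 differs from compound 3 by methyl in place of hydrogen on a saturated chain carbon bound to two saturated chain carbons. Within the data shown here, this is the same kind of change as the one from compound 1 to compound 2, but not the same: there the methyl entered on a saturated chain carbon bound to an oxygen next to a carbonyl group and a saturated chain carbon, whereas here it enters on a saturated chain carbon bound to two saturated chain carbons.

Because the earlier methyl addition gave a number 0.41 log units higher from compound 1 to compound 2 (beyond the scatter), a similar step is expected here, estimated as a number 0.44 log units higher from compound 3 to compound 4 (beyond the scatter). Compound 4 is therefore expected to give about 7.25 in this assay, most likely between 6.9 and 7.6.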

Compound 4, partition coefficient: 7.22
The estimate for compound 4 lay 0.03 log units above the measured number; the measured number falls inside the stated range.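

In this assay the methyl in place of hydrogen gave a step of the same size in both cores (a number 0.41 log units higher from compound 1 to compound 2 (beyond the scatter) and a number 0.41 log units higher from compound 3 to compound 4 (beyond the scatter)), so this change carried over from the core of compound 1 to the core of compound 3, even though it sits on a different kind of saturated chain carbon in each. A change of the group on the carbonyl carbon gave a step beyond the scatter in one pair (a number 0.47 log units lower from compound 2 to compound 4 (beyond the scatter)), whereas a change of that group in another pair gave one within it (a number 0.06 log units lower from compound 1 to compound 4 (within the scatter)), so swapping the group on the carbonyl carbon can matter or not, depending on which pair is read. Among these compounds, this is only one pair in each core, so it sets no rule for other cores or other carbons, and nothing available explains why the two methyl steps match.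

The compounds shown leave open whether the same methyl step would appear on a longer chain, such as pentyl in place of propyl on the carbonyl carbon. They also leave open what an amine or a carboxylic acid at that carbonyl end would do to the number.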